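The compounds below may be only part of what the source reports. "The series", "measured", "known", "first", "only" and "open" are said of these compounds alone.

Compound 1 `Oc1cccc(-c2cc(-c3cccs3)cc(-c3cccc(O)c3)n2)c1` and compound 2 `Oc1ccc(-c2cc(-c3cccs3)cc(-c3cccc(O)c3)n2)cc1` share a core and differ in one group: 4-hydroxyphenyl in place of 3-hydroxyphenyl on an aromatic carbon. In an assay on isolated protein for inhibition of DNA topoisomerase 1 (Homo sapiens), with a stated time of 30 min, tested at 20 uM (on this read-out lower numbers stand for a weaker effect and higher numbers for a stronger effect at the one concentration tested), compound 1 gives 0%, and in this assay compound 2 gives 1.1%, so the step of a number 1.1 percentage points higher from compound 1 to compound 2 (within the scatter) changes little. For compound 3 `Oc1ccc(-c2cc(-c3ccsc3)cc(-c3cccc(O)c3)n2)cc1` the result in this assay is "not determined" (no result reported), so no number is available for it; how its core differs from that of compound 1 is not broken down here. Compound 4 `Oc1ccc(-c2cc(-c3ccsc3)cc(-c3ccc(O)cc3)n2)cc1` is to be measured in this assay, and it differs from compound 3 by the same kind of change: 4-hydroxyphenyl in place of 3-hydroxyphenyl on an aromatic carbon. The surroundings are not identical, since in compound 1 the place is meta to a 3-hydroxyphenyl group and to a thiophen-2-yl group, whereas in compound 3 it is meta to a 4-hydroxyphenyl group and to a thiophen-3-yl group. Because a number 1.1 percentage points higher from compound 1 to compound 2 (within the scatter) stayed within the scatter, only a small step is expected here as well. For compound 4 in this assay the estimated value is 2%, expected to lie between 0% and 12%.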

Compound 4, a percentage reported as inhibition, at one concentration (the size of the read-out at that concentration, not a potency): 7.5%
Compound 4: middle estimate off by 5.5 percentage points, on the low side, and the stated range covers the measured number.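

With no number for compound 3 in this assay, the step to compound 4, which gives 7.5%, cannot be read. The compounds shown leave open what 4-hydroxyphenyl in place of 3-hydroxyphenyl does here, and no evidence bears on this result.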